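Furan attachment point on the chlorinated benzyl arm

A few compounds are considered here, and "the series" means these few. Any claim that something is new, unique, unknown or untested is made for them only; others in the source may bear on it.

Values in an assay on isolated protein for inhibition of ubiquitin carboxyl-terminal hydrolase 7 (Homo sapiens), with stated times of 30 min and 2 h (a lower number here means a stronger inhibitor, a higher number a weaker inhibitor), so far:
compound 1 `Cn1nc2c(=O)n(CC3(O)CCN(Cc4ccc(C5CCCO5)cc4Cl)CC3)cnc2c1-c1ccc(CN)cc1` gives 3820 nM
compound 2 `Cn1nc2c(=O)n(CC3(O)CCN(Cc4ccc(-c5ncco5)cc4Cl)CC3)cnc2c1-c1ccc(CN)cc1` gives 1120 nM
compound 3 `Cn1nc2c(=O)n(CC3(O)CCN(Cc4ccc(-c5ccoc5)cc4Cl)CC3)cnc2c1-c1ccc(CN)cc1` gives 177 nM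

Compound 3 stands lowest of the three numbers in this assay, and both of its steps are beyond the scatter: a 22-fold lower number from compound 1 to compound 3 (1.33 log units; beyond the scatter) and a 6.3-fold lower number from compound 2 to compound 3 (0.80 log units; beyond the scatter). The smaller step of a 3.4-fold lower number from compound 1 to compound 2 (0.53 log units; beyond the scatter) shows that swapping the saturated oxolan-2-yl for an aromatic five-membered ring already helps, and that the furan-3-yl ring of compound 3 adds further to this.

Compound 4 `Cn1nc2c(=O)n(CC3(O)CCN(Cc4ccc(-c5ccco5)cc4Cl)CC3)cnc2c1-c1ccc(CN)cc1` keeps the same atoms and differs only in furan-2-yl in place of furan-3-yl on an aromatic carbon. The step that bears most directly on it is a 6.3-fold lower number from compound 2 to compound 3 (0.80 log units; beyond the scatter), since 1,3-oxazol-2-yl, like furan-2-yl, is joined through the 2 position of the ring, while compound 3 is joined through the 3 position; the two rings differ in a ring nitrogen, so that step is only a partial guide. Some loss against compound 3 is therefore expected, but smaller than the full oxazole gap, so compound 4 is expected at 380 nM in this assay, within 130 nM to 1100 nM, an expected step of a 2.1-fold higher number from compound 3 to compound 4 (0.33 log units; beyond the scatter).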

Compound 4, half-maximal inhibitory concentration: 18.1 nM
Beside the measured number, compound 4's estimate is 21-fold (1.32 log units) above it; the measured number lies below the stated range.
By their numbers in this assay, from the lowest: compound 4; then compound 3; then compound 2; then compound 1.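

In this assay the point of attachment of the furan on the aromatic carbon para to a large group matters by itself, since the two isomers have the same atoms and furan-2-yl in place of furan-3-yl gives a clear gain (a 9.8-fold lower number from compound 3 to compound 4 (0.99 log units; beyond the scatter)). Joining through the 2 position is not enough on its own, as furan-2-yl also stands well apart from 1,3-oxazol-2-yl (a 62-fold lower number from compound 2 to compound 4 (1.79 log units; beyond the scatter)) and from the saturated oxolan-2-yl (a 210-fold lower number from compound 1 to compound 4 (2.32 log units; beyond the scatter)). No measurement at hand explains these gaps.

Open, as far as these compounds go, is whether the gain carries over to thiophen-2-yl, with sulfur in place of the ring oxygen, or to a furan-2-yl ring bearing a methyl group. Also open, from the compounds shown here alone, is whether furan-2-yl keeps this level with fluoro in place of the chloro group.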